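Extending the Alkyl Group on the Aromatic Nitrogen of Compound 1

The source may hold more compounds than are shown below. What is called first, only, known or untested is meant among the compounds shown, and "the series" means these compounds.

Compound 1 `CCC(CC)(c1ccc(OCC(=O)C(C)(C)C)c(C)c1)c1ccc(C(=O)NCC(=O)OC)n1C` is the lower of the two measured numbers: in an assay on HL-60 cells for agonist activity at vitamin D3 receptor (Homo sapiens), with a stated time of 96 h (a higher number here means that more compound is needed for the effect, a lower number that less compound is needed), compound 1 gives 23 nM. Compound 2 `CCC(CC)(c1ccc(OCC(=O)C(C)(C)C)c(C)c1)c1ccc(C(=O)NCCC(=O)OC)n1C`, in this assay, gives 790 nM, and the step of a 34-fold higher number from compound 1 to compound 2 (1.54 log units; beyond the scatter) is large. That step changes the ester-bearing chain on the amide nitrogen, not the group on the ring nitrogen.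

Compound 3 `CCn1c(C(=O)NCC(=O)OC)ccc1C(CC)(CC)c1ccc(OCC(=O)C(C)(C)C)c(C)c1` differs from compound 1 by methyl in place of hydrogen on a saturated chain carbon bound to an aromatic nitrogen, so the same difference, cut one bond further out, reads methyl to ethyl. Among the measured compounds shown here, no measured step touches this part of the shared core, so the only step on record does not bear on the change, and there is no basis for expecting a shift beyond the scatter. The expected step of a 1.3-fold higher number from compound 1 to compound 3 (0.12 log units; within the scatter) is therefore small. The estimate for compound 3 in this assay is 30 nM, within a range from 8 nM to 120 nM.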

Compound 3, half-maximal effective concentration: 1830 nM
Beside the measured number, compound 3's estimate is 61-fold (1.79 log units) below it, outside the stated range (above it).
By their numbers in this assay, from the lowest: compound 1; then compound 2; then compound 3.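

Going from methyl to ethyl on the aromatic nitrogen gives an 80-fold higher number from compound 1 to compound 3 (1.90 log units; beyond the scatter) in this assay, so one added carbon at this place is enough to change the number greatly. Among the compounds shown here, the only earlier step lay in the ester-bearing chain on the amide nitrogen, and this result is the first to show that the group on the aromatic nitrogen matters as well. Nothing on record explains the size of this step.

The compounds shown carry only methyl and ethyl on this nitrogen, so it remains open how a bare hydrogen, a propyl chain or a cyclopropyl group would read in this assay. From the compounds shown here alone, it also remains open whether ethyl would raise the number to a similar degree when paired with the longer ester chain of compound 2.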